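This account rests on a few compounds, and the source may have more. Where it says the series, first, only, none or still open, it means among the compounds named here.

Measured so far:
Compound 1 `CC(C)=CCC/C(C)=C/CC/C(C)=C/CC[C@@H]1[C@@]2(C)CCC(=O)C(C)(C)[C@@H]2CC[C@@]1(C)O` gives 13200 nM in a functional assay on DU-145 cells (Homo sapiens) for cytotoxicity, read by MTT assay, with a stated time of 48 h; a lower number here means a stronger inhibitor, a higher number a weaker inhibitor.
Compound 2 `CC(C)=CCC/C(C)=C/CC/C(C)=C/CC[C@@H]1[C@@]2(C)CC/C(=N\OCc3cn(-c4cccc([N+](=O)[O-])c4)nn3)C(C)(C)[C@@H]2CC[C@@]1(C)O` gives 17400 nM in this assay.

Where compound 2 stands: only two numbers exist in this assay, and the number for compound 2 and that for compound 1 fall within the usual scatter of each other. No order can be read between compound 1 and compound 2 from what has been measured; both sit in the same weak range.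

Next compound: compound 3 `COc1cc(OC)c(-n2cc(CO/N=C3\CC[C@]4(C)[C@@H](CC/C=C(\C)CC/C=C(\C)CCC=C(C)C)[C@](C)(O)CC[C@H]4C3(C)C)nn2)c(OC)c1` differs from compound 2 in one place.
2,4,6-trimethoxyphenyl in place of 3-nitrophenyl on an aromatic nitrogen

Among the measured compounds shown here, no step between measured compounds that differ in one place is on hand, so nothing speaks directly to this exchange. For the measured compounds named here, the one comparison available, compound 1 against compound 2, showed no movement beyond the scatter in this assay. The step of a 1.2-fold lower number from compound 2 to compound 3 (0.06 log units; within the scatter) is therefore expected to be small, with no direction favoured and likely not beyond the scatter. Compound 3 is estimated to give 15000 nM in this assay, with a range from 6000 nM to 40000 nM.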

Compound 3, half-maximal inhibitory concentration: 11100 nM
Compound 3: middle estimate off by 1.4-fold (0.13 log units), on the high side, and the stated range covers the measured number.
By their numbers in this assay, from the lowest: compounds 3, 1 and 2 (each within the scatter of the next).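

On the aromatic nitrogen of the five-membered aromatic ring with 3 nitrogen, 2,4,6-trimethoxyphenyl in place of 3-nitrophenyl gives, in this assay, a 1.6-fold lower number from compound 2 to compound 3 (0.20 log units; within the scatter). Among the compounds shown here, this is the first reading taken at this position itself: a group of 12 heavy atoms with 3 hydrogen-bond acceptors and a group of 9 heavy atoms with 2 hydrogen-bond acceptors are not separated by this assay, and both compounds stay in the same weak range. No measurement on hand bears on why these two groups read alike.

Going by these compounds, with only these two aryl groups at this place, it remains open whether a group of another kind on the same nitrogen, such as a plain methyl, a longer alkyl chain, or a phenyl carrying an amine or a carboxylic acid, would move the number beyond the scatter in this assay. On these data alone, it also remains open whether a phenyl with a single methoxy group would read like these two, so the series cannot yet say whether this position responds to any exchange at all.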